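Swapping a pyridinyloxy arm for methylpiperazine on the nitrile core

The compounds below may be only part of what the source reports. "The series", "measured", "known", "first", "only" and "open" are said of these compounds alone.

Among the measured compounds shown here, in an assay on isolated protein for inhibition of Aromatase (Homo sapiens), read by fluorescence, tested at 1 uM (on this read-out lower numbers stand for less inhibition and higher numbers for more inhibition at the one concentration tested (going by the name of the read-out)), compound 2 `N#Cc1ccc(Oc2cccnc2)cc1Oc1cccnc1` gives 81%, the higher of the two numbers known so far. Compound 1 `N#Cc1ccc(Oc2cccnc2)cc1F` gives 15% in this assay, and the step of a number 66 percentage points higher from compound 1 to compound 2 (beyond the scatter) shows how much the added group matters. Compound 3 `CN1CCN(c2cc(Oc3cccnc3)ccc2C#N)CC1` is not yet measured; it differs from compound 2 by 4-methylpiperazin-1-yl in place of (pyridin-3-yl)oxy on an aromatic carbon. For the measured compounds named here, only that one step bears on the change, and it removes the very group that brought the large rise, so a drop is expected, of size a number 46 percentage points lower from compound 2 to compound 3 (beyond the scatter). Compound 3 is therefore estimated at 35%, within 10% to 70%.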

Compound 3, a percentage reported as inhibition, at one concentration (the size of the read-out at that concentration, not a potency): 8%
The estimate for compound 3 lay 27 percentage points above the measured number; the measured number lies below the stated range.
By their numbers in this assay, from the lowest: compounds 3 and 1 (each within the scatter of the next); then compound 2.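

Putting 4-methylpiperazin-1-yl in place of (pyridin-3-yl)oxy on this aromatic carbon gives a number 73 percentage points lower from compound 2 to compound 3 (beyond the scatter), even though the two groups match in heavy-atom count, so a six-membered ring of that size is not enough to keep the high number. Replacing fluoro with the same group gives a number 7 percentage points lower from compound 1 to compound 3 (within the scatter), so here the piperazine offers no gain over fluoro. No available evidence explains this difference. As far as these compounds go, it remains open whether a phenoxy group, which keeps the oxygen link and an aromatic ring but lacks the ring nitrogen, would retain the high number.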